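The source may hold more compounds than are shown below. What is called first, only, known or untested is meant among the compounds shown, and "the series" means these compounds.

Of the compounds shown here, three built on one shared core have been measured. In a functional assay on MCF7 cells (Homo sapiens) for antiproliferative activity (a lower number here means a stronger inhibitor of growth, a higher number a weaker inhibitor of growth), compound 1 `Oc1ccc(-c2nc3ccccc3s2)cc1O` gives 2190 nM. Compound 2 `Oc1ccc(-c2nc3cc(F)ccc3s2)cc1O` carries a fluoro in place of hydrogen on an aromatic carbon, and in this assay compound 2 gives 720 nM, a change of a 3.0-fold lower number from compound 1 to compound 2 (0.48 log units; beyond the scatter). Compound 3 `COc1ccc(-c2nc3cc(F)ccc3s2)cc1O` differs from compound 2 by a methyl in place of hydrogen on an oxygen on an aromatic ring; in this assay compound 3 gives 500 nM, a step of a 1.4-fold lower number from compound 2 to compound 3 (0.16 log units; within the scatter). Among these three numbers compound 2 holds the second highest, clearly apart from compound 1 but close to compound 3.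

Compound 4 `COc1cc(-c2nc3cc(F)ccc3s2)ccc1O` has not yet been measured. It differs from compound 2 in one place: methyl in place of hydrogen on an oxygen on an aromatic ring. Among the measured compounds shown here, the only measured step that bears on this change is the matching one from compound 2 to compound 3, a 1.4-fold lower number from compound 2 to compound 3 (0.16 log units; within the scatter), which stayed within the scatter. A similar outcome is expected here: no step beyond the scatter, perhaps a slightly lower number. Compound 4 is therefore estimated to give about 600 nM, within a range from 250 nM to 1500 nM. The step this estimate means, a 1.2-fold lower number from compound 2 to compound 4 (0.08 log units; within the scatter), is expected to remain within the scatter.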

Compound 4, concentration for 50% growth inhibition: 750 nM
Beside the measured number, compound 4's estimate is 1.3-fold (0.10 log units) below it; the range from low to high includes it.
By their numbers in this assay, from the lowest: compounds 3, 2 and 4 (each within the scatter of the next); then compound 1.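

Among the compounds shown here, with a 1.0-fold higher number from compound 2 to compound 4 (0.02 log units; within the scatter) in this assay, the hydroxy to methoxy change now stays within the scatter at a second oxygen, not only at the one changed in compound 3. Each of the two hydroxy groups of compound 2 has thus been capped with a methyl singly, and neither change moved the number beyond the scatter, so in this small set a free hydrogen on either single oxygen is not needed to keep the growth inhibition of compound 2. No measurement given here explains why this change is tolerated at both oxygens.

On these data alone, what remains open is whether the same holds with methyl on both oxygens at once, since each compound here keeps one hydroxy group. Also open, as far as these compounds go, is how a longer chain such as ethoxy, or an amine in place of a hydroxy group, would read in this assay.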